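Swapping an Aryl Arm for an Acetamide Chain

The source may report more compounds than this note shows. Statements on the series, on what has been measured and on what is new or still open speak of the compounds shown alone.

Compound 1 `COc1ccc(CCCNCc2c(OC)cc(Oc3ccc(Nc4ccccc4)cc3)cc2OC)cc1` — 6890 nM
Compound 2 `COc1cc(Oc2cccc(Nc3ccccc3)c2)cc(OC)c1CNCc1ccc(F)cc1` — 2750 nM

Of the compounds shown here, two have been measured in a functional assay on HT-29 cells (Homo sapiens) for inhibition, read by MTT assay, with a stated time of 72 h; on this read-out lower numbers stand for stronger inhibition and higher numbers for weaker inhibition. Compound 1 gives 6890 nM, while compound 2 gives 2750 nM. Compound 2 thus holds the lower of the two numbers, and compound 1 stands higher by a gap that lies beyond the usual scatter of this kind of measurement.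

The unmeasured compound 3 `COc1cc(Oc2cccc(Nc3ccccc3)c2)cc(OC)c1CNCCNC(C)=O` differs from compound 2 in one place: acetamidomethyl in place of 4-fluorophenyl on a saturated chain carbon bound to an amine nitrogen. Among the measured compounds shown here, no measured pair shows this exchange, so its effect in this assay is unknown. Compound 3 is nonetheless expected to give a somewhat higher number than compound 2, a step of a 1.8-fold higher number from compound 2 to compound 3 (0.26 log units; within the scatter) that may well stay within the scatter. On that basis compound 3 is estimated at 5000 nM in this assay, within a range from 1500 nM to 20000 nM.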

Compound 3, half-maximal inhibitory concentration: 3960 nM
The estimate for compound 3 lay 1.3-fold (0.10 log units) above the measured number; the measured number falls inside the stated range.
By their numbers in this assay, from the lowest: compounds 2, 3 and 1 (each within the scatter of the next, the first and the last beyond it).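

In this assay, putting acetamidomethyl in place of 4-fluorophenyl on a saturated chain carbon bound to an amine nitrogen amounts to a 1.4-fold higher number from compound 2 to compound 3 (0.16 log units; within the scatter). Among the compounds shown here, this is the first one-place comparison, and it shows that an arm with no ring, carrying a hydrogen-bond donor and a hydrogen-bond acceptor, can stand at this place instead of a six-membered aromatic ring of carbon only, with compound 2 and compound 3 remaining indistinguishable on this read-out. Nothing measured here accounts for this outcome.

The compounds shown leave open how a carboxylic acid, a primary amine or a longer chain ending in the same acetamide would read at this place. They also leave open whether the same exchange would give a similar result on the core of compound 1.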